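Removing the Methyl from the Fused Ring of Compound 1

The source may report more compounds than this note shows. Statements on the series, on what has been measured and on what is new or still open speak of the compounds shown alone.

Among the compounds with values here, compound 1 `Cn1ccc2c(Oc3ccc(NC(=O)c4cn(-c5ccc(Br)cc5F)c5ccccc5c4=O)cc3F)ccnc21` gives 2510 nM in a functional assay on HepG2 cells (Homo sapiens) for inhibition, read by MTT assay, with a stated time of 72 h (on this read-out higher numbers stand for weaker inhibition and lower numbers for stronger inhibition), the lower of the two numbers known, yet within the scatter of compound 2 `COc1ccc(-n2cc(C(=O)Nc3ccc(Oc4ccnc5c4ccn5C)c(F)c3)c(=O)c3ccccc32)cc1`, which gives 3750 nM in this assay. Within the data shown here, the single measured step, a 1.5-fold higher number from compound 1 to compound 2 (0.17 log units; within the scatter), alters a different part of the molecule and stays within the scatter. Compound 3 `O=C(Nc1ccc(Oc2ccnc3[nH]ccc23)c(F)c1)c1cn(-c2ccc(Br)cc2F)c2ccccc2c1=O` differs from compound 1 by hydrogen in place of methyl on an aromatic nitrogen. Among the measured compounds shown here, no measured step touches that site, so compound 3 is expected to shift this assay by no more than the scatter, a 1.0-fold lower number from compound 1 to compound 3 (0.00 log units; within the scatter). The estimate for compound 3 in this assay is 2500 nM, with a range from 900 nM to 7000 nM.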

Compound 3, half-maximal inhibitory concentration: 2200 nM
For compound 3 the middle estimate is 1.1-fold (0.06 log units) above the measured one; measured number inside the range.
By their numbers in this assay, from the lowest: compounds 3, 1 and 2 (each within the scatter of the next).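

Hydrogen in place of methyl on the aromatic nitrogen gives the first measured step at this site in this assay: a 1.1-fold lower number from compound 1 to compound 3 (0.06 log units; within the scatter). With the 4-bromo-2-fluorophenyl group held in place, methyl and hydrogen at this position cannot be told apart on this read-out. No independent measurement bears on this result.

The compounds shown leave open whether a longer chain, such as propyl, or a chain ending in an amine would also leave the number within the scatter. They also leave open whether the same swap behaves alike in the 4-methoxyphenyl compound 2.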